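A few compounds are considered here, and "the series" means these few. Any claim that something is new, unique, unknown or untested is made for them only; others in the source may bear on it.

Measured in a functional assay on 1321-N1 cells for agonist activity at P2Y purinoceptor 4 (Homo sapiens), read by scintillation counting and inositol phosphate accumulation; on this read-out lower numbers stand for an effect already at smaller amounts and higher numbers for an effect only at larger amounts of compound:
Compound 1 `O=C(O)CCCO/N=c1/ccn([C@@H]2O[C@H](COP(=O)(O)OP(=O)(O)OP(=O)(O)O)[C@@H](O)[C@H]2O)c(=O)[nH]1` gives 470 nM.
Compound 2 `COc1ccc(CCCO/N=c2/ccn([C@@H]3O[C@H](COP(=O)(O)OP(=O)(O)OP(=O)(O)O)[C@@H](O)[C@H]3O)c(=O)[nH]2)cc1` gives 23 nM.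

Compound 1 holds the highest of the two numbers in this assay; the nearest is compound 2, reached by a 20-fold lower number from compound 1 to compound 2 (1.31 log units; beyond the scatter). Compound 3 `O=c1[nH]/c(=N\OCCCc2ccsc2)ccn1[C@@H]1O[C@H](COP(=O)(O)OP(=O)(O)OP(=O)(O)O)[C@@H](O)[C@H]1O` is not yet measured. Its difference from compound 1: thiophen-3-yl in place of carboxy on a saturated chain carbon, three bonds along the chain from an oxygen on an unsaturated carbon. Among the measured compounds shown here, the only step that bears on it is the one from compound 1 to compound 2, where 4-methoxyphenyl replaced carboxy on a saturated chain carbon, three bonds along the chain from an oxygen on an unsaturated carbon, a large drop in this assay. A drop of similar size is therefore expected, a 12-fold lower number from compound 1 to compound 3 (1.07 log units; beyond the scatter). For compound 3 in this assay the estimate is 40 nM, with a range of 12 nM to 130 nM.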

Compound 3, half-maximal effective concentration: 20 nM
Beside the measured number, compound 3's estimate is 2.0-fold (0.30 log units) above it; low and high end bracket the measured number.
By their numbers in this assay, from the lowest: compounds 3 and 2 (each within the scatter of the next); then compound 1.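

At the saturated chain carbon three bonds along the chain from an oxygen on an unsaturated carbon, the large drop on replacing carboxy is not tied to 4-methoxyphenyl: thiophen-3-yl gives a 24-fold lower number from compound 1 to compound 3 (1.37 log units; beyond the scatter) in this assay as well. Thiophen-3-yl in place of 4-methoxyphenyl gives a 1.2-fold lower number from compound 2 to compound 3 (0.06 log units; within the scatter) and the two groups cannot be told apart here. No measured data bearing on the reason for this result are available.

Open, going by these compounds, is whether the low numbers need an aromatic ring at all, or whether cyclohexyl or an amine at this place gives similar values. Also open, on these data alone, is how a longer chain carrying thiophen-3-yl would read.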